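A few compounds are considered here, and "the series" means these few. Any claim that something is new, unique, unknown or untested is made for them only; others in the source may bear on it.

Compound 1 `[N-]=[N+]=N[C@@H]1C(n2ccc(=O)[nH]c2=O)[Se][C@H](CO)[C@H]1O` is the starting point. In a functional assay on T47D cells (Homo sapiens) for cytotoxicity, read by sulforhodamine B assay (a higher number here means a weaker inhibitor, a lower number a stronger inhibitor), compound 1 gives > 100000 nM, which is a limit of the assay and not a number, so compound 1 stands only at a limit here. Compound 2 `[N-]=[N+]=N[C@@H]1C(n2cc(I)c(=O)[nH]c2=O)[Se][C@H](CO)[C@H]1O` carries an iodo in place of hydrogen on an aromatic carbon. In this assay compound 2 gives > 100000 nM, again a limit rather than a number. The step that the two limits leave unreadable from compound 1 to compound 2 therefore cannot be sized because both values sit at the limit of > 100000 nM in this assay, at which 2 of the 2 values shown sit. Compound 3 `O=c1ccn(C2[Se][C@H](CO)[C@@H](O)[C@@H]2O)c(=O)[nH]1` differs from compound 1 in one place: hydroxy in place of azido on a saturated ring carbon, a hydroxy in place of azido on a saturated ring carbon. Going by the values given here, no measured step covers this exchange, and the only measured step is unreadable, so the numbers point in no direction. Compound 3 is therefore expected to give 150000 nM, within 50000 nM to 500000 nM. The implied step, a step that the limit leaves unreadable from compound 1 to compound 3, is expected to be none beyond the scatter.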

Compound 3, half-maximal inhibitory concentration: > 100000 nM
Compound 3: no number, only a limit; the forecaster's own chance of this, stated with the estimate: 85%; the middle value lies beyond the limit too.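

The value of compound 3 is also a limit and not a number, so the step from compound 1 to compound 3 cannot be read, because all the values sit at the same limit: (the limit of > 100000 nM in this assay, at which 3 of the 3 values shown sit). In this assay the compounds shown leave open which change to the shared core would give a real number.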